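From methoxy to bromo: one step, one open question

This account rests on a few compounds, and the source may have more. Where it says the series, first, only, none or still open, it means among the compounds named here.

Values in a functional assay on MCF7 cells (Homo sapiens) for antiproliferative activity, read by MTT assay, with a stated time of 48 h; a lower number here means a stronger inhibitor, a higher number a weaker inhibitor:
- Compound 1 `COc1ccc(C(=O)/C=C/c2cc(Br)cc(Br)c2Oc2c([N+](=O)[O-])cc(C(F)(F)F)cc2[N+](=O)[O-])cc1`: 3.53 ug/mL
- Compound 2 `COc1ccc(C(=O)/C=C/c2cc(Cl)cc(Cl)c2Oc2c([N+](=O)[O-])cc(C(F)(F)F)cc2[N+](=O)[O-])cc1`: 2.69 ug/mL
- Compound 3 `COc1ccc(C(=O)/C=C/c2cccc(Br)c2Oc2c([N+](=O)[O-])cc(C(F)(F)F)cc2[N+](=O)[O-])cc1`: 2.32 ug/mL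

The values of compound 1, compound 2 and compound 3 all lie within the usual scatter of one another, so compound 1 holds no distinct rank among them.

Compound 4 `O=C(/C=C/c1cc(Br)cc(Br)c1Oc1c([N+](=O)[O-])cc(C(F)(F)F)cc1[N+](=O)[O-])c1ccc(Br)cc1` differs from compound 1 in one place: bromo in place of methoxy on an aromatic carbon. This is bromo in place of methoxy on an aromatic carbon, turning the 4-methoxyphenyl into a 4-bromophenyl. Among the measured compounds shown here, no measured compound shows a change at this place, so the data give no direct guide to this swap.

For the measured compounds named here, the only measured step in a single place swaps hydrogen in place of bromo on an aromatic carbon, at a different place in the molecule. Resting on the small size of a 1.5-fold lower number from compound 1 to compound 3 (0.18 log units; within the scatter), no step beyond the scatter is expected in this assay, though this is a weak basis.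

The expected step is a 1.0-fold lower number from compound 1 to compound 4 (0.00 log units; within the scatter). For compound 4 the estimated value is 3.5 ug/mL, with an expected range from 1.5 ug/mL to 8 ug/mL.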

Compound 4, half-maximal inhibitory concentration: 2.87 ug/mL
Compound 4: middle estimate off by 1.2-fold (0.09 log units), on the high side, and the stated range covers the measured number.
By their numbers in this assay, from the lowest: compounds 3, 2, 4 and 1 (each within the scatter of the next).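

In this assay, among the compounds shown here, the change from 4-methoxyphenyl to 4-bromophenyl gives a 1.2-fold lower number from compound 1 to compound 4 (0.09 log units; within the scatter) and so provides the first direct reading at this position, which the earlier compounds left untouched. For this one pair, methoxy and bromo cannot be told apart, even though methoxy has two heavy atoms and a hydrogen-bond acceptor while bromo has one heavy atom and no acceptor. No measurement shown here explains this outcome.

A single swap on the dibromo compound cannot show whether the position tolerates change more broadly, or whether the same swap would behave alike with the other halogen patterns. Also open, on these data alone, is how an amine, a carboxylic acid or a longer alkyl chain on this aromatic carbon would fare.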